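Trimming a Butylamino Chain on a Shared Core

The source may report more compounds than this note shows. Statements on the series, on what has been measured and on what is new or still open speak of the compounds shown alone.

Two measured compounds share one core. Compound 1 `CCOC(=O)c1c(C)oc2nc(Nc3ccccc3)nc(N3CCC(C)CC3)c12` is the stronger of the pair: in a functional assay on A549 cells (Homo sapiens) for cytotoxicity, read by MTT assay, with a stated time of 48 h (on this read-out higher numbers stand for weaker inhibition and lower numbers for stronger inhibition), compound 1 gives 800 nM. Compound 2 `CCCCNc1nc(Nc2cccc(C)c2)nc2oc(C)c(C(=O)OCC)c12` stands at the higher of the two numbers, and so is the weaker inhibitor: in this assay compound 2 gives 9000 nM, a gap to compound 1 that lies well beyond the usual scatter. Compound 1 and compound 2 differ in more than one place, so no single change can be credited for that gap.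

Compound 3 `CCOC(=O)c1c(C)oc2nc(Nc3cccc(C)c3)nc(NC(C)C)c12` differs from compound 2 in one place only: isopropyl in place of butyl on a nitrogen on an aromatic ring. Within the data shown here, no measured pair here isolates such a swap of one short chain for another, so the expected step from compound 2 to compound 3 is a 1.1-fold lower number from compound 2 to compound 3 (0.05 log units; within the scatter), that is, none beyond the scatter. Compound 3 is therefore estimated at 8000 nM, with a range from 3000 nM to 25000 nM.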

Compound 3, half-maximal inhibitory concentration: 8600 nM
Compound 3: middle estimate off by 1.1-fold (0.03 log units), on the low side; measured number inside the range.
By their numbers in this assay, from the lowest: compound 1; then compounds 3 and 2 (each within the scatter of the next).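

Replacing butylamino with isopropylamino on the shared core gives a 1.0-fold lower number from compound 2 to compound 3 (0.02 log units; within the scatter) in this assay and so leaves the number unchanged within normal variation. Among these compounds, this is the first reading that isolates the group on this nitrogen, since the earlier pair differed in more than one place, and it shows that a butyl and an isopropyl chain read alike here. Nothing measured here explains why these two chains match.

Going by these compounds, how a longer chain such as octyl, or a chain ending in an amine or a carboxylic acid, would read on this nitrogen remains open. Compound 1 still differs from compound 2 in more than one place, so the gap between them cannot yet be assigned to any single change.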